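The source may hold more compounds than are shown below. What is called first, only, known or untested is meant among the compounds shown, and "the series" means these compounds.

Measured in an ADME assay on A549 cells (Homo sapiens) for cytotoxicity, read by resazurin assay, with a stated time of 48 h; on this read-out lower numbers stand for higher toxicity in this test and higher numbers for lower toxicity in this test:
- Compound 1 `CC(C)Nc1ccc(NC(=O)c2cc(Cl)ccc2O)c(Cl)c1`: 11000 nM
- Compound 2 `O=C(Nc1ccc(NCc2ccc(Cl)cc2)cc1Cl)c1cc(Cl)ccc1O`: 59700 nM

Compound 2 holds the higher of the two values. Compound 3 `COc1ccc(CNc2ccc(NC(=O)c3cc(Cl)ccc3O)c(Cl)c2)cc1` has methoxy in place of chloro on an aromatic carbon, para to a large group: methoxy in place of chloro on an aromatic carbon. Within the data shown here, only one measured step bears on this, a 5.4-fold higher number from compound 1 to compound 2 (0.73 log units; beyond the scatter), and it is modest. It replaced isopropyl with 4-chlorobenzyl, so it does not test this exchange directly. No step beyond the scatter is therefore expected in this assay, with a slight lean towards a lower number. The expected change is a 1.4-fold lower number from compound 2 to compound 3 (0.15 log units; within the scatter). For compound 3 the estimated value is 42000 nM, with an expected range of 15000 nM to 100000 nM.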

Compound 3, half-maximal cytotoxic concentration: 80700 nM
Estimate against measurement, compound 3: 1.9-fold (0.28 log units) below; the range from low to high includes it.
By their numbers in this assay, from the lowest: compound 1; then compounds 2 and 3 (each within the scatter of the next).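

In this assay, methoxy in place of chloro on the aromatic carbon para to a large group gives a 1.4-fold higher number from compound 2 to compound 3 (0.13 log units; within the scatter) and so stays within the scatter, even though methoxy brings a hydrogen-bond acceptor that chloro lacks. The separation from compound 1 also holds with this second benzyl group, as a 7.3-fold higher number from compound 1 to compound 3 (0.87 log units; beyond the scatter) stands beyond the scatter, as 4-chlorobenzyl did. Nothing measured here explains either step. On these data alone, whether an amine or a carboxylic acid on this same carbon would also stay within the scatter of compound 2 remains open.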